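Methylation pattern on two nitrogens in a benzanilide sulfonamide series

The compounds below may be only part of what the source reports. "The series", "measured", "known", "first", "only" and "open" are said of these compounds alone.

Measured so far:
compound 1, `CC(C)S(=O)(=O)Nc1ccc(N(C)C(=O)c2ccccc2)cc1`, 0.1 mg/kg
compound 2, `CC(C)S(=O)(=O)N(C)c1ccc(NC(=O)c2ccccc2)cc1`, 0.01 mg/kg

Both compounds were tested in a functional assay on the whole organism with Mus musculus as the target, with a stated time of 20 min; a higher number here means that more compound is needed for the effect, a lower number that less compound is needed. Compound 1 gives 0.1 mg/kg, compound 2 gives 0.01 mg/kg. Compound 2 therefore stands at the lowest number of the two; its nearest neighbour is compound 1 with the higher number, and that gap lies beyond the scatter. Among the measured compounds shown here, the two compounds carry a single methyl each, on different nitrogens, so no single-point step connects them and nothing is known about either methyl on its own.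

Compound 3, `CC(C)S(=O)(=O)N(C)c1ccc(N(C)C(=O)c2ccccc2)cc1`, carries methyl on both nitrogens. Relative to compound 2 the change is methyl in place of hydrogen on an amide-type nitrogen. For the measured compounds named here, no step of this kind is known, so the expectation rests on the spread of the two numbers alone. In this assay compound 3 is expected to give 0.03 mg/kg, with a range of 0.01 mg/kg to 0.1 mg/kg. The expected step is a 3.0-fold higher number from compound 2 to compound 3 (0.48 log units; beyond the scatter), a modest move toward a higher number, barely beyond the scatter.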

Compound 3, minimum effective dose: 0.01 mg/kg
The estimate for compound 3 lay 3.0-fold (0.48 log units) above the measured number; low and high end bracket the measured number.
By their numbers in this assay, from the lowest: compounds 2 and 3 (each within the scatter of the next); then compound 1.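

In this assay, methyl in place of hydrogen on the amide-type nitrogen is tolerated once the sulfonamide nitrogen carries methyl (no change at the digits printed from compound 2 to compound 3 (within the scatter)), so this position now has a first reading, and the added methyl has no effect on the number beyond the scatter. Methyl in place of hydrogen on a sulfonamide nitrogen, with methyl already on the amide-type nitrogen, gives a much larger step (a 10-fold lower number from compound 1 to compound 3 (1.00 log units; beyond the scatter)), which places the difference between compound 1 and compound 2 in a single-point comparison for the first time, though each nitrogen has been read in only one setting. No measured property of these compounds bears on the contrast between the two nitrogens.

Going by these compounds, the step on the sulfonamide nitrogen remains open with hydrogen on the amide-type nitrogen, and so does the step on the amide-type nitrogen with hydrogen on the sulfonamide nitrogen, as both readings would need the compound with hydrogen on both nitrogens. Also open, on these data alone, is whether a longer chain such as ethyl, or a chain ending in an amine, on either nitrogen would hold the number of compound 3 in this assay, this assay.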